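Swapping Chloro for Ethyl on a Short-Lived Core

A few compounds are considered here, and "the series" means these few. Any claim that something is new, unique, unknown or untested is made for them only; others in the source may bear on it.

Compound 1, `CCC(CC)Nc1nc(OC)c(-c2ccc(Cl)cc2Cl)nc1C`: 0.283 h
Compound 2, `CCc1nc(NC(CC)CC)c(Cl)nc1-c1ccc(Cl)cc1Cl`: < 0.0167 h, a limit of the assay

In an in vitro ADME assay on microsomes (Rattus norvegicus) for metabolic stability (a lower number here means that the compound disappears faster, a higher number that the compound lasts longer), compound 1 gives 0.283 h. Compound 2 sits at the limit of < 0.0167 h in this assay, at which 1 of the 2 values shown sits, so its half-life is known only as a limit, not as a number. Compound 3, `CCc1nc(-c2ccc(Cl)cc2Cl)c(CC)nc1NC(CC)CC`, differs from compound 2 by ethyl in place of chloro on an aromatic carbon. Going by the values given here, no measured pair shows this change, so the step is estimated rather than read: from compound 2 to compound 3 it is expected to be an at least 1.1-fold higher number from compound 2 to compound 3 (0.07 log units; that floor lies within the scatter), small and likely within the scatter. Compound 3 is therefore estimated at 0.02 h, with a range from 0.008 h to 0.08 h.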

Compound 3, half-life: 0.07 h
The estimate for compound 3 lay 3.5-fold (0.54 log units) below the measured number; low and high end bracket the measured number.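

The change from chloro to ethyl on the aromatic carbon next to the ring nitrogen gives an at least 4.1-fold higher number from compound 2 to compound 3 (0.62 log units; beyond the scatter) in this assay and so shows that this one position can shift the half-life beyond the usual scatter. Only a floor can be given for the step, as compound 2 is known by a limit and not by a number: the limit of < 0.0167 h in this assay, at which 1 of the 3 values shown sits.

From the compounds shown here alone, how a longer chain such as propyl, or an amine, would fare on this same carbon stays open. Compound 1 differs from compound 3 in more than one place, so it cannot show how much of its longer half-life comes from this position.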